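The compounds below may be only part of what the source reports. "The series", "measured", "known", "first", "only" and "open" are said of these compounds alone.

Measured compounds:
compound 1 `O=C(COc1cccc2ccccc12)N/N=C/c1cccc(O)c1` — 3.73
compound 2 `O=C(COc1cccc2ccccc12)N/N=C/c1cccc(Br)c1` — 4.81
compound 3 `C/C(=N\NC(=O)COc1cccc2ccccc12)c1ccc(Br)cc1` — 3.61

In a physicochemical assay for lipophilicity, measured as octanol-water partition (on this read-out higher numbers stand for higher lipophilicity and lower numbers for lower lipophilicity), compound 2 gives 4.81, and compound 1 gives 3.73. The change between them, (hydroxy in place of bromo on an aromatic carbon), made a step of a number 1.08 log units lower from compound 2 to compound 1 (beyond the scatter). Compound 4 `C/C(=N\NC(=O)COc1cccc2ccccc12)c1ccc(O)cc1` is not yet measured in this assay. Going by the values given here, it differs from compound 3 by hydroxy in place of bromo on an aromatic carbon; this is the same kind of change as the one from compound 2 to compound 1, but not the same, since in compound 1 the hydroxy sits meta to a large group and in compound 4 it sits para to a large group. The difference between the core of compound 3 and the core of compound 2 is not broken down here. In this assay compound 3 gives 3.61. Compound 4 is expected to show a step of a number 1.06 log units lower from compound 3 to compound 4 (beyond the scatter), resting on the earlier step of a number 1.08 log units lower from compound 2 to compound 1 (beyond the scatter). The estimate for compound 4 is 2.55, between 2.1 and 3.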

Compound 4, partition coefficient: 4.44
Estimate against measurement, compound 4: 1.89 log units below, and the stated range ends below it.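

In this assay, hydroxy in place of bromo on an aromatic carbon made a step of a number 0.83 log units higher from compound 3 to compound 4 (beyond the scatter) but a step of a number 1.08 log units lower from compound 2 to compound 1 (beyond the scatter) on the other core. The change therefore did not carry from one core to the other: the two steps run in opposite directions, and each lies beyond the scatter. The two pairs differ both in core and in where the hydroxy sits, so they do not show which of these matters, and no measurement at hand bears on the reason.

Still open, as far as these compounds go, is whether 4-bromophenyl to 4-hydroxyphenyl would follow the same direction on the core of compound 2, which would separate core from place. Also open, from the compounds shown here alone, is how an amine or a carboxylic acid in place of the bromo would read in this assay on either core.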